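The source may hold more compounds than are shown below. What is called first, only, known or untested is meant among the compounds shown, and "the series" means these compounds.

Compound 1, `CC(C)=CC[C@@H](OC(=O)C1CCCO1)C1=CC(=O)c2c(O)ccc(O)c2C1=O`, gives 10500 nM in a functional assay on DU-145 cells (Homo sapiens) for cytotoxicity, read by MTT assay; a lower number here means a stronger inhibitor, a higher number a weaker inhibitor.
Compound 2, `CC(C)=CC[C@@H](OC(=O)C1CCCCO1)C1=CC(=O)c2c(O)ccc(O)c2C1=O`, gives 24700 nM.
Compound 3, `CCCC(C)(O)CC(=O)O[C@H](CC=C(C)C)C1=CC(=O)c2c(O)ccc(O)c2C1=O`, gives 75000 nM.

Compound 3 stands highest of the three numbers, a 3.0-fold higher number from compound 2 to compound 3 (0.48 log units; beyond the scatter) and a 7.1-fold higher number from compound 1 to compound 3 (0.85 log units; beyond the scatter). Compound 4, `CC(=O)OC(C)CO[C@H](CC=C(C)C)C1=CC(=O)c2c(O)ccc(O)c2C1=O`, differs from compound 3 by 2-acetoxypropyl in place of (2-hydroxy-2-methylpentyl)carbonyl on an oxygen on a saturated carbon. Among the compounds with values here, none of the measured steps touches this kind of change: each of them, a 2.4-fold higher number from compound 1 to compound 2 (0.37 log units; beyond the scatter) included, exchanges the group on the carbonyl carbon, whereas here the whole ester is replaced by an ether-linked chain. Within the data shown here, the only guide is that compound 3 is already the weakest, so little room remains upward, and the step is expected to stay within the scatter, a 1.7-fold lower number from compound 3 to compound 4 (0.22 log units; within the scatter), with a wide range. Compound 4 is therefore estimated at 45000 nM, between 15000 nM and 130000 nM.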

Compound 4, half-maximal inhibitory concentration: 16600 nM
Compound 4: the middle estimate sits 2.7-fold (0.43 log units) above what was measured; the range from low to high includes it.
By their numbers in this assay, from the lowest: compounds 1, 4 and 2 (each within the scatter of the next, the first and the last beyond it); then compound 3.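

Exchanging (2-hydroxy-2-methylpentyl)carbonyl for the ether-linked 2-acetoxypropyl on this oxygen gives in this assay a clear drop (with a 4.5-fold lower number from compound 3 to compound 4 (0.65 log units; beyond the scatter) as the step), so a carbonyl directly on this oxygen is not needed for numbers at this level. The same chain stands level with both ring-bearing esters (with a 1.5-fold lower number from compound 2 to compound 4 (0.17 log units; within the scatter) and a 1.6-fold higher number from compound 1 to compound 4 (0.20 log units; within the scatter) as the steps). No evidence is available that bears on this result.

The compounds shown leave open whether the ether link or the acetoxy group accounts for the step from compound 3, and how an amine or a carboxylic acid in place of 2-acetoxypropyl would read.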